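Macrolide series: epimer at a ring stereocentre, cytotoxicity

The compounds below may be only part of what the source reports. "The series", "measured", "known", "first", "only" and "open" are said of these compounds alone.

Compound 1 `CC(=O)O[C@@H]1/C=C/C(C)=C/C[C@H](O)/C=C/C(C)=C/[C@@H](NC(=O)[C@H](C)O)[C@]2(C)C(=O)O[C@H](C1)[C@@H](C)C2=O`, compound 2 `CC1=C\C[C@H](O)/C=C/C(C)=C/[C@@H](NC(=O)[C@H](C)O)[C@]2(C)C(=O)O[C@H](C[C@H](O)/C=C/1)[C@@H](C)C2=O` and compound 3 `CC1=C\C[C@H](O)/C=C/C(C)=C/[C@@H](NC(=O)[C@H](C)O)[C@H](C)C(=O)/C(C)=C/C[C@H](O)\C=C\1` have been tested in a functional assay on A549 cells (Homo sapiens) for cytotoxicity, read by MTT assay, with a stated time of 72 h; a higher number here means a weaker inhibitor, a lower number a stronger inhibitor. Compound 1 gives only a limit, > 100000 nM. Compound 2 likewise gives only a limit, > 100000 nM. Compound 3 stands at the same limit, > 100000 nM, so no number is known for it in this assay; all that is known is the limit of > 100000 nM in this assay, at which 3 of the 3 values shown sit.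

Compound 4 `CC1=C\C[C@H](O)/C=C/C(C)=C/[C@@H](NC(=O)[C@H](C)O)[C@@H](C)C(=O)/C(C)=C/C[C@H](O)\C=C\1` is to be measured in this assay. It differs from compound 3 by the two compounds have the same atoms and bonds and differ only in configuration as drawn: 1 of 10 stereo elements differ; a stereocentre at a saturated ring carbon is drawn S in compound 3 and R in compound 4.

Going by the values given here, no step between measured compounds is available, and the three results are all limits, so no size of step can be read from the data. The expected step is a number no higher from compound 3 to compound 4 (the limit leaves the size open), none beyond the scatter. Compound 4 is expected to give 100000 nM, in the range 30000 nM to 300000 nM, most probably again as a limit.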

Compound 4, half-maximal inhibitory concentration: > 100000 nM
Compound 4 gave a limit, no number; the forecaster's own chance of this, stated with the estimate: 80%; the middle value lies on the limit itself.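

No step can be read between compound 3 and compound 4: both give only a limit, not a number, in this assay. The compounds shown leave open whether the configuration at this saturated ring carbon affects cytotoxicity at all.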